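A few compounds are considered here, and "the series" means these few. Any claim that something is new, unique, unknown or untested is made for them only; others in the source may bear on it.

Measured compounds:
compound 1 `O=C(Nc1nn[nH]n1)c1cccc(Br)n1` — 48%
compound 2 `Cc1cc(Cl)cc(C(=O)Nc2nn[nH]n2)n1` — 100%
compound 3 `CSc1ccc(C(=O)Nc2nn[nH]n2)nc1` — 29%

In a functional assay on the whole organism for inhibition, with Rattus norvegicus as the target, at a dose of 10 mg/kg by the oral route (on this read-out higher numbers stand for a stronger effect at the one dose given and lower numbers for a weaker effect), compound 2 gives 100%, the highest of the three numbers. Its nearest neighbour is compound 1, which in this assay gives 48%, a gap beyond the scatter; the furthest is compound 3, which in this assay gives 29%, again beyond the scatter. Within the data shown here, no pair of these three compounds differs in only one place, so no single-change step can be read off among the measured set.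

Compound 4 `COc1cc(C)nc(C(=O)Nc2nn[nH]n2)c1` is not yet measured. It differs from compound 2 in one place: methoxy in place of chloro on an aromatic carbon, on an aromatic carbon of a six-membered aromatic ring with one nitrogen, meta to a methyl group and opposite the ring nitrogen.

Among the measured compounds shown here, with no measured step of this kind, the expectation rests on compound 2 sitting at the top of the range with 100% and on the lower numbers of compound 1 and compound 3. A downward step of moderate size in this assay is expected, and the step of a number 30 percentage points lower from compound 2 to compound 4 (beyond the scatter) is the estimate. Compound 4 is expected to give about 70% in this assay, within 35% to 100%.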

Compound 4, a percentage reported as inhibition, in the whole organism at one dose (the size of the read-out at that dose, not a potency): 20%
Compound 4: the middle estimate sits 50 percentage points above what was measured; the measured number lies below the stated range.
By their numbers in this assay, from the lowest: compounds 4 and 3 (each within the scatter of the next); then compound 1; then compound 2.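

In this assay, among these compounds, the position opposite the ring nitrogen proves sensitive to the group it carries: with the methyl group and the rest of the core held constant, methoxy in place of chloro gives a number 80 percentage points lower from compound 2 to compound 4 (beyond the scatter) as the first single-change step. The high response of compound 2 therefore does not survive this one change on the shared core, and compound 4 gives only 20% at the same oral dose. No available evidence bears on why this change has so large an effect.

Open, on these data alone, is how a fluoro, a nitrile or an amine at this position would read, and with it whether chloro is unusually favourable here or methoxy is unusually poor. Among the compounds shown here, also open is whether the step keeps its size with an ethyl group or a hydrogen in place of the methyl group, as the single pair holds that methyl group fixed.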